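The compounds below may be only part of what the source reports. "The series", "measured", "known", "first", "only" and "open" are said of these compounds alone.

Compound 3 `Cc1ccc(NC(=O)c2ccc(OC[C@@H]3CN(C)c4ccccc4O3)cc2Cl)cc1CC(=O)O` gives the lowest number of the three measured compounds in a functional assay on CHO cells for antagonist activity at prostaglandin D2 receptor (Mus musculus), read by cAMP accumulation (on this read-out higher numbers stand for weaker inhibition and lower numbers for stronger inhibition), at 3.9 nM. Compound 2 `Cc1ccc(CC(=O)O)cc1NC(=O)c1ccc(OC[C@@H]2CN(C)c3ccccc3O2)cc1Cl` comes nearest, giving 6 nM, and the gap between them stays within the scatter. Compound 1 `CN1C[C@@H](COc2ccc(C(=O)Nc3cccc(CC(=O)O)c3)c(Cl)c2)Oc2ccccc21` lies furthest away, giving 20 nM; that gap reads a 5.1-fold lower number from compound 1 to compound 3 (0.71 log units; beyond the scatter), and the related step of a 3.3-fold lower number from compound 1 to compound 2 (0.52 log units; beyond the scatter) points the same way.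

Compound 4 `CN1C[C@@H](COc2ccc(C(=O)Nc3ccc(F)c(CC(=O)O)c3)c(Cl)c2)Oc2ccccc21` differs from compound 3 by the change (fluoro in place of methyl on an aromatic carbon), on an aromatic carbon of a six-membered aromatic ring of carbon only, ortho to a carboxymethyl group and para to a large group. Among the measured compounds shown here, the steps that bear on this are the two that put a methyl onto compound 1 to give compound 2 and compound 3; both lowered the number by a modest, clear amount. Taking the methyl away again is therefore expected to cost some of that gain, and the fluoro that enters is not covered by any measured step. The expected step is a 2.3-fold higher number from compound 3 to compound 4 (0.36 log units; beyond the scatter), a modest rise. Compound 4 is thus estimated at 9 nM, with a range from 3 nM to 27 nM.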

Compound 4, half-maximal inhibitory concentration: 50 nM
Compound 4: the middle estimate sits 5.6-fold (0.74 log units) below what was measured; measured number above the stated range.
By their numbers in this assay, from the lowest: compounds 3 and 2 (each within the scatter of the next); then compound 1; then compound 4.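

At this place, ortho to a carboxymethyl group, fluoro does not behave as a stand-in for methyl: exchanging one heavy atom for another, with no hydrogen-bond donor or acceptor gained or lost, gives a 13-fold higher number from compound 3 to compound 4 (1.11 log units; beyond the scatter). Fluoro also does not match plain hydrogen here, as the comparison with the unsubstituted ring gives a 2.5-fold higher number from compound 1 to compound 4 (0.40 log units; beyond the scatter), while methyl at the same place gave a 5.1-fold lower number from compound 1 to compound 3 (0.71 log units; beyond the scatter), so the direction of the step depends on the group that enters. Methyl on the other ring position also compares favourably with this fluoro, with an 8.3-fold higher number from compound 2 to compound 4 (0.92 log units; beyond the scatter).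

No measurement at hand explains why methyl and fluoro part so far here. Going by these compounds, whether a chloro, an ethyl or a methoxy group at this place would side with methyl or with fluoro stays open.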